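From Fluoro to Dimethylsulfamoyl: Expecting a Lower Tolerance

This account rests on a few compounds, and the source may have more. Where it says the series, first, only, none or still open, it means among the compounds named here.

Measured in an ADME assay on LLC-MK2 cells (Macaca mulatta) for cytotoxicity, read by spectrophotometry and crystal violet staining, with a stated time of 4 days; a higher number here means that more compound is tolerated, a lower number that less compound is tolerated:
- Compound 1 `CC(C)n1ncc2c(C(=O)Nc3cccc(C(N)=O)c3)cc(-c3cccs3)nc21`: 25000 nM
- Compound 2 `CNS(=O)(=O)c1cccc(NC(=O)c2cc(-c3cccs3)nc3c2cnn3C(C)C)c1`: 25000 nM
- Compound 3 `CC(C)n1ncc2c(C(=O)Nc3cccc(F)c3)cc(-c3cccs3)nc21`: > 200000 nM

Compound 3 stands at > 200000 nM, which is a limit of the assay and not a number.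

Compound 4 `CC(C)n1ncc2c(C(=O)Nc3cccc(S(=O)(=O)N(C)C)c3)cc(-c3cccs3)nc21` differs from compound 3 in one place, with dimethylsulfamoyl in place of fluoro on an aromatic carbon.

Among the measured compounds shown here, three measured steps bear on this change. The two that end on fluoro are an at least 8.0-fold higher number from compound 1 to compound 3 (0.90 log units; beyond the scatter) and an at least 8.0-fold higher number from compound 2 to compound 3 (0.90 log units; beyond the scatter). Between the two larger groups, the step is no change at the digits printed from compound 1 to compound 2 (within the scatter). Compound 4 has a group closest by name to the methylsulfamoyl of compound 2, which gives 25000 nM. Leaving fluoro should therefore reverse those steps and give a lower number in this assay, meaning less compound is tolerated. The expected step is an at least 6.6-fold lower number from compound 3 to compound 4 (0.82 log units; beyond the scatter). For compound 4 the estimated value is 30000 nM, with an expected range from 12000 nM to 90000 nM.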

Compound 4, half-maximal cytotoxic concentration: > 200000 nM
Compound 4: no number, only a limit (the forecaster's own chance of this, stated with the estimate: 12%); middle value at least 6.6-fold (0.82 log units) away from the limit.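

In this assay compound 4 gives > 200000 nM, which is a limit of the assay and not a number. The extra methyl alone is enough to change the result, with an at least 8.0-fold higher number from compound 2 to compound 4 (0.90 log units; beyond the scatter), and replacing carbamoyl with dimethylsulfamoyl gives an at least 8.0-fold higher number from compound 1 to compound 4 (0.90 log units; beyond the scatter). Among these four compounds, the two groups that keep a hydrogen on their nitrogen, carbamoyl and methylsulfamoyl, give the lower values, and no compound shown goes against this.

The step from compound 3 to compound 4 cannot be read, and fluoro and dimethylsulfamoyl cannot be ranked, since both compounds sit at the same limit: the limit of > 200000 nM in this assay, at which 2 of the 4 values shown sit. Going by these compounds, whether that nitrogen hydrogen is what matters stays open, as does how an amine or a carboxylic acid at this place would read in this assay.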